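The source may report more compounds than this note shows. Statements on the series, on what has been measured and on what is new or still open speak of the compounds shown alone.

Measured compounds in a functional assay on HOP-62 cells (Homo sapiens) for cytotoxicity, read by sulforhodamine B assay, with a stated time of 48 h; a lower number here means a stronger inhibitor of growth, a higher number a weaker inhibitor of growth:
- compound 1 `O=C(COc1ccc(/C=C2\SC(=O)NC2=O)cc1)Nc1nc2ccccc2s1`: 28800 nM; 170 nM (2 entries)
- compound 2 `O=C(COc1ccc(/C=C2\SC(=O)NC2=O)cc1)Nc1ncc([N+](=O)[O-])s1`: a limit only, < 100000 nM
- compound 3 `O=C(COc1ccc(/C=C2\SC(=O)NC2=O)cc1)Nc1ccccn1`: 2290 nM

Within the data shown here, compound 3 holds the only single number in this assay. Compound 1 is split across two widely separated entries (the several entries of compound 1 in this assay, 28800 nM; 170 nM (2 entries)), and compound 2 sits at the limit (the limit of < 100000 nM in this assay, at which 1 of the 3 values shown sits), so the step that the limit leaves unreadable from compound 2 to compound 3 cannot be sized. Compound 4 `Cc1cc(NC(=O)COc2ccc(/C=C3\SC(=O)NC3=O)cc2)no1` differs from compound 3 by 5-methyl-1,2-oxazol-3-yl in place of pyridin-2-yl on an amide-type nitrogen, at the same amide-type nitrogen where the unreadable step was taken. Among the measured compounds shown here, no measured step bears on this change with a readable size. The step from compound 3 to compound 4 is therefore expected to be small, a 1.7-fold higher number from compound 3 to compound 4 (0.24 log units; within the scatter), with no firm direction. Compound 4 is estimated at 4000 nM in this assay, within 800 nM to 25000 nM.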

Compound 4, concentration for 50% growth inhibition: < 100000 nM
Compound 4 gave a limit, no number (the forecaster's own chance of this, stated with the estimate: 20%); the middle value does not contradict the limit.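

Among these compounds, compound 4 returns only the limit < 100000 nM and so no new step from compound 2 or compound 3 to compound 4 can be read. The compounds shown leave open how 5-methyl-1,2-oxazol-3-yl compares with pyridin-2-yl on the amide-type nitrogen.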